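Dichloro substitution on the purine core of compound 1

The source may report more compounds than this note shows. Statements on the series, on what has been measured and on what is new or still open speak of the compounds shown alone.

Measured compounds:
compound 1 `ClCc1ccc(Cn2cnc3c(Cl)ncnc32)cc1`, 50 nM
compound 2 `ClCc1ccccc1Cn1cnc2c(Cl)nc(Cl)nc21`, 3310 nM
compound 3 `ClCc1ccccc1Cn1cnc2c(Cl)ncnc21`, 15500 nM

In a functional assay on NCI-H460 cells (Homo sapiens) for cytotoxicity, read by sulforhodamine B assay, with a stated time of 48 h (on this read-out lower numbers stand for stronger inhibition of growth and higher numbers for weaker inhibition of growth), compound 1 gives 50 nM, the lowest of the three numbers; compound 2 gives 3310 nM and compound 3 gives 15500 nM, both well above it.

Compound 4 `ClCc1ccc(Cn2cnc3c(Cl)nc(Cl)nc32)cc1` is not yet measured. It differs from compound 1 by chloro in place of hydrogen on an aromatic carbon. Among the measured compounds shown here, the one step that bears on this change is the pair of compound 2 and compound 3, where the same position carries chloro in compound 2 and hydrogen in compound 3: a 4.7-fold higher number from compound 2 to compound 3 (0.67 log units; beyond the scatter). Read in the direction of the present change, hydrogen to chloro, that step lowered the number by a modest amount, on a core bearing a different benzyl substitution pattern. For the measured compounds named here, no second example exists, so the transfer to the series of compound 1 is uncertain.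

For compound 4 a modestly lower number than for compound 1 is therefore expected, a 3.3-fold lower number from compound 1 to compound 4 (0.52 log units; beyond the scatter). The estimate for compound 4 is 15 nM, with a range from 4 nM to 60 nM.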

Compound 4, concentration for 50% growth inhibition: 2400 nM
Compound 4: the middle estimate sits 160-fold (2.20 log units) below what was measured; the measured number lies above the stated range.
By their numbers in this assay, from the lowest: compound 1; then compounds 4 and 2 (each within the scatter of the next); then compound 3.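

Chloro in place of hydrogen on the aromatic carbon between two ring nitrogen atoms has no single direction across this series in this assay. Among the compounds shown here, on the core of compound 1, the change gives a 48-fold higher number from compound 1 to compound 4 (1.68 log units; beyond the scatter), opposite in direction to the only earlier step and much larger. The outcome of this change therefore depends on the core that carries it, and the two cores differ in the benzyl substitution pattern: the same change on two cores in this assay, a 4.7-fold higher number (0.67 log units; beyond the scatter) from compound 2 to compound 3 and a 48-fold lower number (1.68 log units; beyond the scatter) from compound 4 to compound 1, 220-fold (2.35 log units) apart, beyond the scatter of two such steps

From the compounds shown here alone, whether the loss on the core of compound 1 is specific to chloro or extends to other groups on this carbon, such as an amine or a methoxy group, remains open. Going by these compounds, the contribution of the chloromethyl group to the low number of compound 1, compared with a hydroxymethyl group for instance, also remains open.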